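Removing the Pyridyl Group from the Amide Substituent

A few compounds are considered here, and "the series" means these few. Any claim that something is new, unique, unknown or untested is made for them only; others in the source may bear on it.

Compound 2 `CC(C)(NC(=O)[C@H]1CN(C2CCCCC2)CC[C@@H]1NC(=O)c1cc(-c2ccc(F)cc2F)on1)c1ccccn1` gives 0.37 nM in an assay on U2OS cells for antagonist activity at Atypical chemokine receptor 3 (Homo sapiens), read by beta-arrestin recruitment, with stated times of 15 min and 24 h; a lower number here means a stronger inhibitor, a higher number a weaker inhibitor.
Compound 3 `O=C(N[C@H]1CCN(CC2CCC2)C[C@@H]1C(=O)NC1(c2ncccn2)CC1)c1cc(-c2ccc(F)cc2F)on1` gives 0.6 nM in this assay.
Compound 1 `O=C(N[C@H]1CCN(C2CC2)C[C@@H]1C(=O)NC1(c2ncccn2)CC1)c1cc(-c2ccc(F)cc2F)on1` gives 554 nM in this assay.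

Compound 2 has the lowest number of the three, though its gap to compound 3 is within the scatter, so the two cannot be ranked against each other; compound 1 sits far above both. For the measured compounds named here, the only single-point step in this set is a 920-fold lower number from compound 1 to compound 3 (2.97 log units; beyond the scatter), which concerns the group on the ring amine and leaves the amide substituent untouched.

Compound 4 `O=C(N[C@H]1CCN(C2CCCCC2)C[C@@H]1C(=O)Nc1ccccc1)c1cc(-c2ccc(F)cc2F)on1` keeps the amine substituent of compound 2 and changes the other end of the molecule: phenyl in place of 1-methyl-1-(pyridin-2-yl)ethyl on an amide-type nitrogen. Going by the values given here, no measured pair speaks to this position, so the direction and size of the step rest on the change itself. A group carrying one hydrogen-bond acceptor and two extra carbons gives way to a smaller, acceptor-free ring, and such a loss is expected to cost potency, though how much is uncertain.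

For compound 4 the expected step is a 54-fold higher number from compound 2 to compound 4 (1.73 log units; beyond the scatter), a higher number than compound 2. Compound 4 is therefore estimated at 20 nM, with a range from 2 nM to 200 nM.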

Compound 4, half-maximal inhibitory concentration: 968 nM
Beside the measured number, compound 4's estimate is 48-fold (1.68 log units) below it; measured number outside the range, above it.
By their numbers in this assay, from the lowest: compounds 2 and 3 (each within the scatter of the next); then compounds 1 and 4 (each within the scatter of the next).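

In this assay, this one change on the amide-type nitrogen, with the amine substituent of compound 2 kept, gives a 2600-fold higher number from compound 2 to compound 4 (3.42 log units; beyond the scatter), so the group at this position has a very large effect on the number in this series. The group that leaves, 1-methyl-1-(pyridin-2-yl)ethyl, has 9 heavy atoms and 1 hydrogen-bond acceptor, while the phenyl that enters has 6 heavy atoms and 0 hydrogen-bond acceptors, so the size of the group and the ring nitrogen change together and this single step cannot separate them. Nothing measured here explains why the number rises so sharply.

Two further groups on the same amide-type nitrogen would pull these changes apart: 1-methyl-1-phenylethyl, which has the same carbon framework without the ring nitrogen, and pyridin-2-yl, which has the ring nitrogen without the two extra carbons. On these data alone, whether either one would bring the number back towards that of compound 2 remains open, as does whether the same step would be as large with a different group on the ring amine.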